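From Ester to Acid on a Weak Inhibitor

The source may hold more compounds than are shown below. What is called first, only, known or untested is meant among the compounds shown, and "the series" means these compounds.

Of the compounds shown here, three have been measured in an assay for inhibition of 15-hydroxyprostaglandin dehydrogenase [NAD(+)] (Homo sapiens), read by fluorescence, with a stated time of 15 min, in the presence of a further agent that is not named here; a lower number here means a stronger inhibitor, a higher number a weaker inhibitor. Compound 1 `CCCC[S+]([O-])c1nc2ccc(-c3cccs3)nc2s1` gives 1230 nM in this assay. Compound 2 `CCCC[S+]([O-])c1sc2nc(-c3nccs3)cc(-c3cccc(CO)c3)c2c1N` gives 4.3 nM in this assay. Compound 3 `CCOC(=O)c1sc2nc(-c3cccs3)cc(-c3ccccc3)c2c1N` carries an ethoxycarbonyl group on the shared core, and for compound 3 this assay reports only a limit, > 7500 nM, not a number. Compound 3 thus stands at the limit of > 7500 nM in this assay, at which 1 of the 3 values shown sits, the weak end of what has been seen so far, with no exact value of its own.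

Compound 4 `Nc1c(C(=O)O)sc2nc(-c3cccs3)cc(-c3ccccc3)c12` differs from compound 3 in one place: hydrogen in place of ethyl on an oxygen next to a carbonyl group. For the measured compounds named here, no measured pair of compounds shows this change, so nothing observed tells how large a step it brings. Starting from a compound that already sits at a limit, the step that the limit leaves unreadable from compound 3 to compound 4 is expected to be none beyond the scatter, or, if anything, a shift toward weaker inhibition. Compound 4 is therefore estimated at 15000 nM, within a range of 5000 nM to 60000 nM, and it is more likely than not that this assay again reports only a limit for compound 4.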

Compound 4, half-maximal inhibitory concentration: > 7500 nM
Compound 4: no number, only a limit; the forecaster's own chance of this, stated with the estimate: 70%; the middle value does not contradict the limit.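

Compound 3 and compound 4 are each reported only as a limit, not as a number, so the size of the step between them cannot be read: the limit of > 7500 nM in this assay, at which 2 of the 4 values shown sit. The compounds shown leave open whether changing ethoxycarbonyl to carboxy on the shared core alters inhibition at all, and in which direction.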